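Nitro to hydroxy on the shared core: minimum effective dose

A few compounds are considered here, and "the series" means these few. Any claim that something is new, unique, unknown or untested is made for them only; others in the source may bear on it.

Of the compounds shown here, two have numbers so far in a functional assay on the whole organism (strain Swiss albino) with Mus musculus as the target, with a stated time of 0.5 h; on this read-out lower numbers stand for an effect already at smaller amounts and higher numbers for an effect only at larger amounts of compound. Compound 1, `O=C(N/N=C/c1ccccc1[N+](=O)[O-])Nc1cccc2ccccc12`, gives 300 mg/kg in this assay, which is the highest of the two numbers recorded. Compound 2, `COc1cc(/C=N/NC(=O)Nc2cccc3ccccc23)cc(OC)c1OC`, gives 100 mg/kg in this assay, a figure that lies beyond the scatter from compound 1, so compound 2 shows an effect at a smaller amount than compound 1. Going by the values given here, no pair of measured compounds differs in only one place, so no single-point step has been observed yet.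

Compound 3, `O=C(N/N=C/c1ccccc1O)Nc1cccc2ccccc12`, has not been measured in this assay. It differs from compound 1 in one place: hydroxy in place of nitro on an aromatic carbon. Among the compounds with values here, the two measured compounds give no step of this kind to lean on, and the change replaces one substituent with another at the same place on the same ring.

The expectation for compound 3 in this assay is therefore a step of a 1.2-fold lower number from compound 1 to compound 3 (0.08 log units; within the scatter), not beyond the scatter in either direction. Compound 3 is estimated at 250 mg/kg in this assay, with a range from 100 mg/kg to 600 mg/kg.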

Compound 3, minimum effective dose: 300 mg/kg
Estimate against measurement, compound 3: 1.2-fold (0.08 log units) below; low and high end bracket the measured number.
By their numbers in this assay, from the lowest: compound 2; then compounds 1 and 3 (each within the scatter of the next).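

In this assay, going by these compounds alone, hydroxy in place of nitro on an aromatic carbon, ortho to a large group, gives no change at the digits printed from compound 1 to compound 3 (within the scatter), the only single-place step available so far. At this position, therefore, replacing nitro (3 heavy atoms, 0 hydrogen-bond donors, 2 hydrogen-bond acceptors) with hydroxy (1 heavy atom, 1 hydrogen-bond donor, 1 hydrogen-bond acceptor) leaves the minimum effective dose within the scatter, so these differences in size and hydrogen-bonding counts come with no resolved shift in this read-out. No measurement on hand explains this flat step.

The compounds shown leave open whether an amine or a carboxylic acid on this same aromatic carbon would also stay within the scatter of compound 1 or would give a step beyond it. As far as these compounds go, it also remains open whether hydroxy or nitro on another carbon of this six-membered aromatic ring would give the same flat result, since this single step describes one position and one exchange on the shared core.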